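The source may hold more compounds than are shown below. What is called first, only, known or untested is meant among the compounds shown, and "the series" means these compounds.

Measured in a functional assay on 3T3-L1 cells (Mus musculus) for inhibition, with a stated time of 20 min, tested at 20 uM; on this read-out lower numbers stand for less inhibition and higher numbers for more inhibition at the one concentration tested (going by the name of the read-out):
Compound 1 `COc1ccc(Cn2cc(CN(Cc3cn(S(=O)(=O)c4ccc(C)cc4)c4ccccc34)S(=O)(=O)c3ccc(C)cc3)nn2)c(OC)c1` gives 7.6%.
Compound 2 `Cc1ccc(S(=O)(=O)N(Cc2cn(Cc3cc(F)ccc3F)nn2)Cc2cn(S(=O)(=O)c3ccccc3)c3ccccc23)cc1` gives -6.5%.

Compound 1 thus stands highest of the two numbers, with compound 2 lower than it by more than the usual scatter. No step between the measured compounds is shown. Compound 3 `COc1ccc(Cn2cc(CN(Cc3cn(S(=O)(=O)c4ccc(C)cc4)c4ccccc34)S(=O)(=O)c3ccc(C)cc3)nn2)c(OC)c1OC` differs from compound 1 by methoxy in place of hydrogen on an aromatic carbon. Both measured numbers sit near no inhibition at this single concentration, and nothing measured shows how adding a methoxy group moves this read-out, so the step of a number 0.4 percentage points higher from compound 1 to compound 3 (within the scatter) is expected to stay within the scatter. Compound 3 is therefore estimated at 8%, within a range from -10% to 26%.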

Compound 3, a percentage reported as inhibition, at one concentration (the size of the read-out at that concentration, not a potency): -18%
For compound 3 the middle estimate is 26 percentage points above the measured one; the whole stated range lies above it.
By their numbers in this assay, from the lowest: compound 3; then compound 2; then compound 1.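

Placing a methoxy group on the ring carbon ortho to two methoxy groups, which turns 2,4-dimethoxyphenyl into 2,3,4-trimethoxyphenyl, is the first single-place change available here. In this assay it gives a number 25.6 percentage points lower from compound 1 to compound 3 (beyond the scatter) and so shows that this ring position is not indifferent to substitution. Nothing available explains this step.

The compounds shown leave open whether a hydroxyl or an amine at this position would move the number in the same direction. They also leave open whether a methoxy group here would have this effect without the two methoxy groups already on the ring.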